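The source may report more compounds than this note shows. Statements on the series, on what has been measured and on what is new or still open speak of the compounds shown alone.

Going by the values given here, in a functional assay on CEM-SS cells (Homo sapiens) for cytotoxicity (a higher number here means a weaker inhibitor, a lower number a stronger inhibitor), compound 1 `Clc1cc2nc(Cl)n(Cc3ccccc3Cl)c2cc1Cl` gives 70000 nM, the only true number so far. Compound 2 `Clc1cc2nc(Br)n(Cc3ccccc3)c2cc1Cl` gives > 100000 nM in this assay. That value is a limit of the assay and not a number, so compound 2 has no exact position and the size of any step away from it cannot be read directly.

Compound 3 `Clc1cc2nc(Br)n(Cc3ccccc3Cl)c2cc1Cl` is reached from compound 2 by one change: chloro in place of hydrogen on an aromatic carbon. The chloro replaces hydrogen on an aromatic carbon of a six-membered aromatic ring of carbon only, ortho to a large group.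

Among the compounds with values here, no measured step shows what this change does in this assay. Within the data shown here, a modest move towards lower numbers is expected, with the only anchor being compound 1 at 70000 nM. The expected change is an at least 1.5-fold lower number from compound 2 to compound 3 (0.18 log units; that floor lies within the scatter), and it may prove hard to distinguish if the result is again only a limit. For compound 3 the estimated value is 65000 nM, with an expected range of 30000 nM to 100000 nM.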

Compound 3, half-maximal inhibitory concentration: 74000 nM
The estimate for compound 3 lay 1.1-fold (0.06 log units) below the measured number; low and high end bracket the measured number.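

In this assay, going by these compounds alone, chloro in place of hydrogen on an aromatic carbon of a six-membered aromatic ring of carbon only, ortho to a large group, gives an at least 1.3-fold lower number from compound 2 to compound 3 (0.13 log units; that floor lies within the scatter), and this is the first result with bromo on the shared core that reads as a true number. As far as these compounds go, the step can be read only as a floor, and its true size stays unknown, because one end of it is not a number: the limit of > 100000 nM in this assay, at which 1 of the 3 values shown sits. Bromo in place of chloro on an aromatic carbon gives a 1.1-fold higher number from compound 1 to compound 3 (0.02 log units; within the scatter), so with the chloro on the six-membered ring present, these two halogens cannot be told apart in this assay.

From the compounds shown here alone, the size of the chloro step remains open, as does whether bromo and chloro would also match without that ring chloro. Going by these compounds, what an amine, a methoxy group or a carboxylic acid would do at the same ring position, ortho to a large group, also remains open.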